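Aryl swap on the triazole nitrogen of the shared core

The source may report more compounds than this note shows. Statements on the series, on what has been measured and on what is new or still open speak of the compounds shown alone.

Compound 1 `O[C@H](COCCOC[C@@H](O)Cc1cn(Cc2ccc(C(F)(F)F)cc2)nn1)Cc1ccc(-c2ccccc2)cc1` and compound 2 `O=c1[nH]c2ccc(-n3cc(C[C@H](O)COCCOC[C@@H](O)Cc4ccc(-c5ccccc5)cc4)nn3)cc2s1` share a core and differ only in the group on an aromatic nitrogen. In a functional assay on SGC-7901 cells (Homo sapiens) for inhibition, read by MTT assay, with a stated time of 72 h (on this read-out higher numbers stand for weaker inhibition of growth and lower numbers for stronger inhibition of growth), compound 1 gives 8700 nM and compound 2 gives 10500 nM; the step of a 1.2-fold higher number from compound 1 to compound 2 (0.08 log units; within the scatter) lies within the scatter, so compound 2 holds the higher of the two numbers without separating from compound 1. Compound 3 `O[C@H](COCCOC[C@@H](O)Cc1cn(-c2ccc3[nH]ccc3c2)nn1)Cc1ccc(-c2ccccc2)cc1` carries the change (a group of 9 heavy atoms (8 carbon, 1 nitrogen; one five-membered aromatic ring with 1 hetero atom, one six-membered aromatic ring of carbon only) in place of a group of 10 heavy atoms (7 carbon, 1 nitrogen, 1 oxygen, 1 sulfur; one five-membered aromatic ring with 2 hetero atoms, one six-membered aromatic ring of carbon only), on an aromatic nitrogen). Only the earlier swap on that same nitrogen bears on it, and it stayed within the scatter, so in this assay the expected step is a 1.1-fold lower number from compound 2 to compound 3 (0.04 log units; within the scatter), none beyond the scatter. Compound 3 is therefore estimated at 9500 nM, ranging from 4000 nM to 22000 nM.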

Compound 3, concentration for 50% growth inhibition: 45600 nM
For compound 3 the middle estimate is 4.8-fold (0.68 log units) below the measured one; the measured number lies above the stated range.
By their numbers in this assay, from the lowest: compounds 1 and 2 (each within the scatter of the next); then compound 3.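

In this assay, the group on this aromatic nitrogen can shift the number beyond the scatter: 1H-indol-5-yl gives weaker inhibition of growth than the group in compound 2 (a 4.3-fold higher number from compound 2 to compound 3 (0.64 log units; beyond the scatter)) and the 4-(trifluoromethyl)benzyl group in compound 1 (a 5.2-fold higher number from compound 1 to compound 3 (0.72 log units; beyond the scatter)). Among the three groups shown, only 1H-indol-5-yl separates from the others, so this position does not accept every bicyclic aromatic group equally. Nothing available accounts for this step. From the compounds shown here alone, it remains open whether an amine or a carboxylic acid on the 1H-indol-5-yl group would bring the number back towards those of compound 1 and compound 2.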